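Trifluoromethyl for Methyl on the Aryl Arm of Compound 1

This account rests on a few compounds, and the source may have more. Where it says the series, first, only, none or still open, it means among the compounds named here.

Of the compounds shown here, three sharing one core have been measured in a functional assay on BJAB cells (Homo sapiens) for antiproliferative activity, with a stated time of 4 days; on this read-out higher numbers stand for an effect only at larger amounts of compound and lower numbers for an effect already at smaller amounts. Compound 1 `Cc1ccccc1-c1c(C)nn(-c2nc(-c3ccc(Cl)c(Cl)c3)c(SC(C)C)s2)c1C(=O)O` gives 5500 nM in this assay. Compound 2 `Cc1nn(-c2nc(-c3ccc(Cl)c(Cl)c3)c(SC(C)C)s2)c(C(=O)O)c1-c1cnccn1`, carrying pyrazin-2-yl in place of 2-methylphenyl, gives 14000 nM, and compound 3 `Cc1nn(-c2nc(-c3ccc(Cl)c(Cl)c3)c(SC(C)C)s2)c(C(=O)O)c1-c1cc(C#N)cc(C(F)(F)F)c1`, carrying 3-cyano-5-(trifluoromethyl)phenyl instead, gives 3600 nM. Compound 1 thus holds the second highest of the three numbers: its nearest neighbour is compound 3, at a 1.5-fold lower number from compound 1 to compound 3 (0.18 log units; within the scatter), while compound 2 stands further off, at a 2.5-fold higher number from compound 1 to compound 2 (0.41 log units; beyond the scatter). Between compound 2 and compound 3 the step is a 3.9-fold lower number from compound 2 to compound 3 (0.59 log units; beyond the scatter).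

Compound 4 `Cc1nn(-c2nc(-c3ccc(Cl)c(Cl)c3)c(SC(C)C)s2)c(C(=O)O)c1-c1ccccc1C(F)(F)F` has not yet been measured. It differs from compound 1 in a single spot: trifluoromethyl in place of methyl on an aromatic carbon. Both the leaving and the entering groups are small, and the six-membered aromatic ring of carbon only stays in place. Among the compounds with values here, no measured step swaps exactly these two groups. The nearest guide is the step from compound 1 to compound 3, where a trifluoromethyl arrived on that ring together with a nitrile and the number moved only within the scatter, a 1.5-fold lower number from compound 1 to compound 3 (0.18 log units; within the scatter). Exchanging the ring itself for pyrazin-2-yl gave the larger move, a 2.5-fold higher number from compound 1 to compound 2 (0.41 log units; beyond the scatter). Compound 4 is therefore expected to land near compound 1, with a step of a 1.2-fold lower number from compound 1 to compound 4 (0.09 log units; within the scatter), not beyond the scatter. The estimate for compound 4 is 4500 nM, between 2000 nM and 10000 nM.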

Compound 4, half-maximal effective concentration: 5200 nM
Beside the measured number, compound 4's estimate is 1.2-fold (0.06 log units) below it; the range from low to high includes it.
By their numbers in this assay, from the lowest: compounds 3, 4 and 1 (each within the scatter of the next); then compound 2.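

Taken alone, trifluoromethyl in place of methyl on this aromatic carbon, ortho to a large group, gives a 1.1-fold lower number from compound 1 to compound 4 (0.02 log units; within the scatter) in this assay, so the larger group leaves the read-out within the scatter with no nitrile present to confound the comparison. The change of the whole aryl group gives a 1.4-fold higher number from compound 3 to compound 4 (0.16 log units; within the scatter), which puts the three groups built on a six-membered aromatic ring of carbon only close together, while a 2.7-fold lower number from compound 2 to compound 4 (0.43 log units; beyond the scatter) shows pyrazin-2-yl standing apart from 2-(trifluoromethyl)phenyl as well as from the two other aryl groups. No measurement shown here speaks to why methyl and trifluoromethyl read so much alike.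

Going by these compounds, it remains open whether an amine, a methoxy group or a longer chain such as propyl on this same aromatic carbon would stay with compounds 1, 3 and 4 or move away from them. On these data alone, it is equally open whether a pyridinyl group, with fewer ring nitrogens than pyrazin-2-yl, would read like compound 2 or like the three others.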